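Removing the sulfur methyl: from compound 3 to compound 4

The source may report more compounds than this note shows. Statements on the series, on what has been measured and on what is new or still open speak of the compounds shown alone.

Of the compounds shown here, three sharing one core have been tested in an ADME assay on 184B5 cells (Homo sapiens) for cytotoxicity, read by MTT assay, with a stated time of 72 h; a higher number here means a weaker inhibitor of growth, a lower number a stronger inhibitor of growth. Compound 2 `CSc1nc(NCc2ccccc2)c2ccccc2n1` gives 28900 nM. Compound 1 `Sc1nc(NCc2ccccc2)c2ccccc2n1` differs from compound 2 by hydrogen in place of methyl on a sulfur, and in this assay compound 1 gives 49600 nM, which makes a 1.7-fold higher number from compound 2 to compound 1 (0.23 log units; within the scatter). Compound 3 `COc1ccc(CNc2nc(SC)nc3ccccc23)cc1` carries methoxy in place of hydrogen on an aromatic carbon relative to compound 2; in this assay compound 3 gives 85600 nM, so that a 3.0-fold higher number from compound 2 to compound 3 (0.47 log units; beyond the scatter). Within the data shown here, compound 4 `COc1ccc(CNc2nc(S)nc3ccccc23)cc1` has not yet been measured; it differs from compound 3 by hydrogen in place of methyl on a sulfur, the same change as the one leading from compound 2 to compound 1, at the same place. Since the measured step was a 1.7-fold higher number from compound 2 to compound 1 (0.23 log units; within the scatter), the step of a 1.4-fold higher number from compound 3 to compound 4 (0.15 log units; within the scatter) is expected to be of similar size, an expectation resting on that single pair alone. In this assay compound 4 is accordingly estimated at 120000 nM, most likely between 55000 nM and 260000 nM.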

Compound 4, concentration for 50% growth inhibition: 7830 nM
Compound 4: the middle estimate sits 15-fold (1.19 log units) above what was measured, and the stated range ends above it.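

In this assay, hydrogen in place of methyl on the sulfur gives an 11-fold lower number from compound 3 to compound 4 (1.04 log units; beyond the scatter) when the methoxy is present, and this step does not match the one on the core without methoxy: the same change on two cores in this assay, a 1.7-fold higher number (0.23 log units; within the scatter) from compound 2 to compound 1 and an 11-fold lower number (1.04 log units; beyond the scatter) from compound 3 to compound 4, 19-fold (1.27 log units) apart, beyond the scatter of two such steps Methoxy in place of hydrogen on an aromatic carbon gives a 6.3-fold lower number from compound 1 to compound 4 (0.80 log units; beyond the scatter) when the sulfur carries hydrogen, which runs opposite in direction to the step seen when the sulfur carries methyl: the same change on two cores in this assay, a 3.0-fold higher number (0.47 log units; beyond the scatter) from compound 2 to compound 3 and a 6.3-fold lower number (0.80 log units; beyond the scatter) from compound 1 to compound 4, 19-fold (1.27 log units) apart, beyond the scatter of two such steps Neither step therefore carried over from one core to the other in these four compounds, though this single set does not show why, or whether other members of the series would behave alike.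

On these data alone, it remains open whether a chloro or a hydroxy group in place of the methoxy would give a low number like that of compound 4. As far as these compounds go, it is equally open where an ethyl group or a longer chain on the sulfur would fall.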